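Nitro to chloro swap on two cores: cytotoxicity notes

A few compounds are considered here, and "the series" means these few. Any claim that something is new, unique, unknown or untested is made for them only; others in the source may bear on it.

Compound 1 `O=C(NNC(=O)c1ccc([N+](=O)[O-])cc1)c1ccc(-n2cccc2)cc1` and compound 3 `O=C(NNC(=O)c1ccc(-n2cccc2)cc1)c1ccc(Cl)cc1` share one core; compound 2 `O=[N+]([O-])c1ccc(-c2nnc(-c3ccc(-n4cccc4)cc3)o2)cc1` and the unmeasured compound 4 `Clc1ccc(-c2nnc(-c3ccc(-n4cccc4)cc3)o2)cc1` share another. How the core of compound 2 differs from the core of compound 1 is not broken down here.

In an ADME assay on A549 cells (Homo sapiens) for cytotoxicity, read by MTT assay, with a stated time of 72 h (on this read-out higher numbers stand for weaker inhibition and lower numbers for stronger inhibition), compound 1 gives 198000 nM. In this assay compound 3 gives 185000 nM, and in this assay compound 2 gives 258000 nM. All three numbers lie within the usual scatter of one another, so no order among them is claimed.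

Among the compounds with values here, the one measured change is this: chloro in place of nitro on an aromatic carbon It made a 1.1-fold lower number from compound 1 to compound 3 (0.03 log units; within the scatter). The change that carries compound 2 to compound 4 is this: chloro in place of nitro on an aromatic carbon The two place descriptions agree word for word, so it is the same change, made here on the core of compound 2 rather than on the core of compound 1. Among the four compounds it occurs twice in all.

For compound 4 the step from compound 2 is expected to resemble the measured one: a 1.1-fold lower number from compound 2 to compound 4 (0.03 log units; within the scatter) is expected, resting on a 1.1-fold lower number from compound 1 to compound 3 (0.03 log units; within the scatter), which is within the scatter. Within the data shown here, only one example of the change is measured, and it sits on a different core, so the bounds are kept wide. Compound 4 is thus estimated at 241000 nM in this assay, with a range from 120000 nM to 480000 nM.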

Compound 4, half-maximal inhibitory concentration: 256000 nM
The estimate for compound 4 lay 1.1-fold (0.03 log units) below the measured number; low and high end bracket the measured number.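

In this assay, chloro in place of nitro on an aromatic carbon gives a 1.0-fold lower number from compound 2 to compound 4 (0.00 log units; within the scatter), and this step on the core of compound 2 agrees with the earlier step on the core of compound 1: the same change on two cores in this assay, a 1.1-fold lower number (0.03 log units; within the scatter) from compound 1 to compound 3 and a 1.0-fold lower number (0.00 log units; within the scatter) from compound 2 to compound 4, 1.1-fold (0.03 log units) apart, within the scatter of two such steps

The agreement shows that this swap, para to a large group, leaves no readable mark on either core, so a null result carries from one core to the other in this pair of examples. It does not show that a real effect of the swap transfers between the cores, as neither step has a size beyond the scatter that could be carried over. Two pairs of compounds make no rule for the series, and nothing here tells whether a larger step made at this place would repeat on the second core.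

Open, as far as these compounds go, is whether an amine or a carboxylic acid on that aromatic carbon, on either core, would give a step beyond the scatter where nitro and chloro do not. Equally open, from the compounds shown here alone, is whether a longer chain at that place would behave as these two groups do, and whether the flat picture holds in any read-out other than this assay.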